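The source may report more compounds than this note shows. Statements on the series, on what has been measured and on what is new or still open speak of the compounds shown alone.

- Compound 1 `O=C(NCCCCc1ccccc1)c1cccc(C2SCC(=O)N2c2cnccn2)c1`: > 1000 nM
- Compound 2 `O=C(NCCCCc1ccccc1)c1cccc(C2SCC(=O)N2c2ccccc2)c1`: 15.9 nM
- Compound 3 `COc1cc(F)ccc1N1C(=O)CSC1c1cccc(C(=O)NCCCCc2ccccc2)c1`: 71.1 nM

In a functional assay on HOS-TE85 cells (Homo sapiens) for inhibition, read by CCK-8 assay, with a stated time of 72 h (on this read-out lower numbers stand for stronger inhibition and higher numbers for weaker inhibition), compound 1 reads > 1000 nM, which is a limit and not a number. That leaves two true numbers, and compound 3 holds the higher one at 71.1 nM. Its nearest neighbour is compound 2 at 15.9 nM.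

The next compound, compound 4 `O=C(NCCCCc1ccccc1)c1cccc(C2SCC(=O)N2c2ccccc2F)c1`, carries 2-fluorophenyl in place of 4-fluoro-2-methoxyphenyl on an amide-type nitrogen in a ring.

The most relevant measured change is the one that put 4-fluoro-2-methoxyphenyl in place of phenyl, a 4.5-fold higher number from compound 2 to compound 3 (0.65 log units; beyond the scatter), a modest step. The large steps of an at least 62-fold lower number from compound 1 to compound 2 (1.79 log units; beyond the scatter) and an at least 14-fold lower number from compound 1 to compound 3 (1.14 log units; beyond the scatter) say less here, as both start from a limit and remove pyrazin-2-yl, a group that plays no part in this change.

The entering 2-fluorophenyl looks more like the phenyl of compound 2 than the leaving group does. Part of the step to compound 3 may therefore be won back, so a small move towards lower numbers in this assay is expected, though it may barely clear the scatter. The expected change is a 2.4-fold lower number from compound 3 to compound 4 (0.37 log units; beyond the scatter). For compound 4 the estimated value is 30 nM, with an expected range from 10 nM to 90 nM.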

Compound 4, half-maximal inhibitory concentration: 34.1 nM
Compound 4: the middle estimate sits 1.1-fold (0.06 log units) below what was measured; measured number inside the range.
By their numbers in this assay, from the lowest: compound 2; then compound 4; then compound 3. At a limit, above all of these: compound 1.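

In this assay, compound 4 is now tied to its neighbours by two single changes: a 2.1-fold lower number from compound 3 to compound 4 (0.32 log units; beyond the scatter), and a 2.1-fold higher number from compound 2 to compound 4 (0.33 log units; beyond the scatter). This shows that one fluoro on the phenyl ring at the amide-type nitrogen is enough to move the number away from that of compound 2, and that the larger 4-fluoro-2-methoxyphenyl of compound 3 is not needed for such a move, although the fluoro sits at a different ring position in the two groups, so the step from compound 3 cannot be credited to the lost methoxy alone. Compound 4 also joins the other benzene-ring compounds well clear of the pyrazin-2-yl compound, with an at least 29-fold lower number from compound 1 to compound 4 (1.46 log units; beyond the scatter), but that step starts from compound 1 and so rests on a limit, not a true number: the limit of > 1000 nM in this assay, at which 1 of the 4 values shown sits.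

The compounds shown leave open how 2-methoxyphenyl or 4-fluorophenyl alone would read on this nitrogen, which would separate the two parts of that change. They also leave open whether another group on this phenyl ring, such as a hydroxyl or an amine, could bring the number below that of compound 2.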